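The source may hold more compounds than are shown below. What is called first, only, known or untested is meant among the compounds shown, and "the series" means these compounds.

Working notes on the series. Compound 1, `Cc1nc(NC(=O)Cn2nnc(-c3ccccc3)n2)n(-c2ccccc2)n1`, and compound 2, `Cc1cc(NC(=O)Cn2nnc(-c3ccccn3)n2)n(C2CCCCC2)n1`, share an amide-linked tetrazole arm but differ in the substitution on both ends. In an assay on HEK293 cells for activation of Kir3.1/Kir3.2 (Homo sapiens), read by thallium flux (a higher number here means that more compound is needed for the effect, a lower number that less compound is needed), compound 1 gives "not active" (no number reported), so no number stands against it. In this assay compound 2 gives 14600 nM, which is the only number shown so far; compound 2 therefore stands alone as the sole quantified point, with compound 1 as the single further entry without a value.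

Compound 3, `Cc1cc(NC(=O)Cn2nnc(-c3cccc(F)n3)n2)n(C2CCCCC2)n1`, is not yet measured. It differs from compound 2 in one place: fluoro in place of hydrogen on an aromatic carbon. The change is small, one fluorine entering at an aromatic carbon of the pyridin-2-yl ring, giving 6-fluoropyridin-2-yl. Among the measured compounds shown here, with no measured step between any pair to lean on, the expectation for this change is a step of no more than the usual scatter, with no clear direction. The step from compound 2 to compound 3 is estimated as a 1.2-fold lower number from compound 2 to compound 3 (0.09 log units; within the scatter). Compound 3 is thus expected near 12000 nM, within the range 5000 nM to 30000 nM.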

Compound 3, half-maximal effective concentration: > 3000 nM
Compound 3 ended at the assay's limit (the forecaster's own chance of this, stated with the estimate: 25%); the middle value lies beyond the limit too.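

In this assay compound 3 gives > 3000 nM, which is a limit of the assay and not a number. No step from compound 2 to compound 3 can therefore be read: the limit of > 3000 nM in this assay, at which 1 of the 3 values shown sits.

The compounds shown leave open whether fluoro in place of hydrogen on the pyridin-2-yl ring shifts the number in this assay, and in which direction.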